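Nitro versus methoxy on the pendant phenyl of the core

The source may report more compounds than this note shows. Statements on the series, on what has been measured and on what is new or still open speak of the compounds shown alone.

Measured compounds:
compound 1 `O=[N+]([O-])c1cccc(-c2nn(-c3ccccc3)cc2C(Nc2nc3ccccc3s2)c2c(O)ccc3ccccc23)c1`: 43900 nM
compound 2 `Cc1ccc2nc(NC(c3cn(-c4ccccc4)nc3-c3cccc([N+](=O)[O-])c3)c3c(O)ccc4ccccc34)sc2c1`: 38400 nM
compound 3 `COc1cccc(-c2nn(-c3ccccc3)cc2C(Nc2nc3ccccc3s2)c2c(O)ccc3ccccc23)c1`: 16900 nM

In a functional assay on MCF7 cells (Homo sapiens) for antiproliferative activity, read by MTT assay, with a stated time of 48 h (on this read-out lower numbers stand for stronger inhibition and higher numbers for weaker inhibition), compound 3 gives the lowest number of the three, the other two standing beyond the scatter from it. The methyl added on the benzothiazole side gave a 1.1-fold lower number from compound 1 to compound 2 (0.06 log units; within the scatter), so that part of the core tolerates the change without effect.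

Compound 4 `O=[N+]([O-])c1ccc(-c2nn(-c3ccccc3)cc2C(Nc2nc3ccccc3s2)c2c(O)ccc3ccccc23)cc1` keeps the core of compound 3 and changes only the pendant aryl group: 4-nitrophenyl in place of 3-methoxyphenyl on an aromatic carbon. Among the measured compounds shown here, the one measured step that bears on this is a 2.6-fold lower number from compound 1 to compound 3 (0.41 log units; beyond the scatter), which the present change largely reverses, since compound 4 again carries a nitro group on the phenyl ring where compound 3 carries a methoxy. For the measured compounds named here, a return toward the number of compound 1 is therefore expected, though the nitro group now sits at a different ring position and no measured pair tests that.

The step expected is a 2.2-fold higher number from compound 3 to compound 4 (0.35 log units; beyond the scatter). Compound 4 is estimated at 38000 nM, within 14000 nM to 100000 nM.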

Compound 4, half-maximal inhibitory concentration: 14700 nM
Beside the measured number, compound 4's estimate is 2.6-fold (0.41 log units) above it, within the range that was stated.
By their numbers in this assay, from the lowest: compounds 4 and 3 (each within the scatter of the next); then compounds 2 and 1 (each within the scatter of the next).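

In this assay the nitro group alone does not set the number at this position: the step is a 1.1-fold lower number from compound 3 to compound 4 (0.06 log units; within the scatter) for 4-nitrophenyl in place of 3-methoxyphenyl, while the step is a 3.0-fold lower number from compound 1 to compound 4 (0.48 log units; beyond the scatter) for 4-nitrophenyl in place of 3-nitrophenyl. The gap between compound 1 and compound 3 therefore cannot be read as a plain nitro-for-methoxy effect, since compound 4 carries a nitro group and stands within the scatter of compound 3; among these compounds, the ring position of the nitro group changes the result. Nothing available explains this dependence on ring position.

Still open, as far as these compounds go, is how 4-methoxyphenyl compares with 3-methoxyphenyl on the shared core. Also open, from the compounds shown here alone, is whether an amine or a carboxylic acid on the pendant phenyl would move the number in either direction.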